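From chloro to methyl on the aryl ring

The source may hold more compounds than are shown below. What is called first, only, known or untested is meant among the compounds shown, and "the series" means these compounds.

Compound 1 (`O=C1C=C(N2CCN(c3ccccc3Cl)CC2)C(=O)c2ccccc21`) : 28800 nM
Compound 2 (`O=C1C=C(N2CCN(c3ccccc3Cl)CC2)C(=O)c2c(O)cccc21`) : 5200 nM

In a functional assay on L78 cells (Homo sapiens) for antiproliferative activity, read by MTT assay, with a stated time of 72 h (a higher number here means a weaker inhibitor, a lower number a stronger inhibitor), compound 2 at 5200 nM is the lower of the two measured compounds. Compound 3 (`Cc1ccccc1N1CCN(C2=CC(=O)c3cccc(O)c3C2=O)CC1`) has methyl in place of chloro on an aromatic carbon, ortho to a large group (methyl in place of chloro on an aromatic carbon). Within the data shown here, the only measured step, a 5.5-fold lower number from compound 1 to compound 2 (0.74 log units; beyond the scatter) for hydroxy in place of hydrogen, involves a different change, so no measured step bears directly on this one. No step beyond the scatter is therefore expected in this assay, and the expected step is a 1.2-fold higher number from compound 2 to compound 3 (0.06 log units; within the scatter) in size. For compound 3 the estimate is 6000 nM within a range of 2500 nM to 14000 nM as expected bounds.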

Compound 3, half-maximal inhibitory concentration: 15100 nM
Compound 3: middle estimate off by 2.5-fold (0.40 log units), on the low side, outside the stated range (above it).
By their numbers in this assay, from the lowest: compound 2; then compounds 3 and 1 (each within the scatter of the next).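

In this assay, methyl in place of chloro gives a 2.9-fold higher number from compound 2 to compound 3 (0.46 log units; beyond the scatter), so this position on the aromatic ring, ortho to a large group, responds to the exchange of a single heavy atom, with chloro holding the lower number of the pair. The earlier step, made elsewhere in the molecule, could not show this. No measurement available here accounts for the difference. The compounds shown leave open how a methoxy group, a fluoro group or an amine would read at this position.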